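The source may report more compounds than this note shows. Statements on the series, on what has been measured and on what is new or still open speak of the compounds shown alone.

Compound 1, `COc1cc2c(Oc3ccc(NC(=O)c4nn(-c5ccccc5)c(=O)c5ccccc45)cc3F)ccnc2cc1OCCCN1CCCC1`, is the parent of this small set. In a functional assay on MDA-MB-231 cells (Homo sapiens) for cytotoxicity, read by MTT assay, with a stated time of 72 h (a higher number here means a weaker inhibitor, a lower number a stronger inhibitor), compound 1 gives 1130 nM, the second highest of the three numbers to hand. Its two near relatives alter only the phenyl on the ring nitrogen: compound 2, `COc1cc2c(Oc3ccc(NC(=O)c4nn(-c5cccc(F)c5)c(=O)c5ccccc45)cc3F)ccnc2cc1OCCCN1CCCC1`, gives 880 nM in this assay, and compound 3, `COc1cc2c(Oc3ccc(NC(=O)c4nn(-c5ccc(Br)cc5)c(=O)c5ccccc45)cc3F)ccnc2cc1OCCCN1CCCC1`, gives 1160 nM. The steps between them are all small: a 1.3-fold lower number from compound 1 to compound 2 (0.11 log units; within the scatter), a 1.0-fold higher number from compound 1 to compound 3 (0.01 log units; within the scatter) and a 1.3-fold higher number from compound 2 to compound 3 (0.12 log units; within the scatter).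

Compound 4, `COc1cc2c(Oc3ccc(NC(=O)c4nn(-c5ccccc5)c(=O)c5ccccc45)cc3F)ccnc2cc1OCCCN1CCN(C)CC1`, changes a different part of compound 1: 4-methylpiperazin-1-yl in place of pyrrolidin-1-yl on a saturated chain carbon, three bonds along the chain from an oxygen on an aromatic ring. Among the measured compounds shown here, no measured pair in this set touches the amine at the end of that chain, so no step bears directly on this change. For the measured compounds named here, the only guidance is that the three recorded steps, each at the other end of the molecule, all stay within the scatter, and nothing here argues for a shift beyond it in this assay. Compound 4 is therefore expected to sit close to compound 1, with an estimated step of a 1.0-fold lower number from compound 1 to compound 4 (0.01 log units; within the scatter). The estimate for compound 4 is 1100 nM, within a range of 400 nM to 3200 nM.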

Compound 4, half-maximal inhibitory concentration: 1580 nM
Compound 4: the middle estimate sits 1.4-fold (0.16 log units) below what was measured; low and high end bracket the measured number.
By their numbers in this assay, from the lowest: compounds 2, 1, 3 and 4 (each within the scatter of the next).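

The amine at the end of the chain now has a measured step of its own: in this assay, 4-methylpiperazin-1-yl in place of pyrrolidin-1-yl gives a 1.4-fold higher number from compound 1 to compound 4 (0.15 log units; within the scatter). This single change, with its larger six-membered ring and second ring nitrogen, therefore leaves the cellular read-out within the scatter, as the changes on the aromatic nitrogen did. No supporting measurement bears on this result.

Going by these compounds, whether the same holds for a morpholine, a dimethylamino group or a primary amine at the chain end remains open, as does the effect of a longer chain or a shorter one. Also open, on these data alone, is whether 4-methylpiperazin-1-yl would give a similar number when paired with 3-fluorophenyl or 4-bromophenyl on the aromatic nitrogen.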